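The source may hold more compounds than are shown below. What is called first, only, known or untested is meant among the compounds shown, and "the series" means these compounds.

Compound 1 `O=C(NCC1(c2ccccc2)CCCCC1)Nc1ccccc1` is the starting point. Among the measured compounds shown here, in an assay on microsomes from intestine for inhibition of acyl-CoA:cholesterol acyltransferase (Oryctolagus cuniculus) (a higher number here means a weaker inhibitor, a lower number a stronger inhibitor), compound 1 gives 2300 nM, the highest of the two numbers measured so far, so it is the weaker inhibitor of the pair. For the measured compounds named here, its only measured neighbour is compound 2 `O=C(NCC1(c2ccccc2)CCCCC1)Nc1ccccc1C(F)(F)F`, which in this assay gives 200 nM; the step of a 12-fold lower number from compound 1 to compound 2 (1.06 log units; beyond the scatter) is the one change whose effect is known here.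

Compound 3 `CC(C)c1ccc(NC(=O)NCC2(c3ccccc3)CCCCC2)cc1` carries a different change on the same core: isopropyl in place of hydrogen on an aromatic carbon. Going by the values given here, no measured step shows what this group does at this place, so the step from compound 1 to compound 2 is the only guide. It shows that adding a group on that ring can lower the number strongly, but the group and its place differ, so a smaller lowering is expected. For compound 3 the expected step is a 2.9-fold lower number from compound 1 to compound 3 (0.46 log units; beyond the scatter). Compound 3 is therefore estimated at 800 nM, within a range from 300 nM to 2500 nM.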

Compound 3, half-maximal inhibitory concentration: 1500 nM
Compound 3: middle estimate off by 1.9-fold (0.27 log units), on the low side; the range from low to high includes it.
By their numbers in this assay, from the lowest: compound 2; then compounds 3 and 1 (each within the scatter of the next).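

In this assay, isopropyl on an aromatic carbon, para to a large group, gives a 1.5-fold lower number from compound 1 to compound 3 (0.19 log units; within the scatter), so this change cannot be told apart from no change at all. Adding a group to this ring therefore does not by itself bring a strong lowering like the one in the trifluoromethyl step, a 12-fold lower number from compound 1 to compound 2 (1.06 log units; beyond the scatter), and at this place isopropyl brings neither a clear gain nor a clear loss. Nothing measured here explains this result.

Going by these compounds, whether a different group at this same place, such as an amine, a carboxylic acid or a longer chain, would move the number beyond the scatter stays open. On these data alone, it is also open whether isopropyl on another carbon of this ring would behave in the same way.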